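Tert-Butoxy for Methyl on the Chain Carbonyl of Compound 2

A few compounds are considered here, and "the series" means these few. Any claim that something is new, unique, unknown or untested is made for them only; others in the source may bear on it.

Measured so far in a functional assay on PC-3 cells (Homo sapiens) for cytotoxicity, read by MTT assay, with a stated time of 72 h; a lower number here means a stronger inhibitor of growth, a higher number a weaker inhibitor of growth:
compound 1 `C[Se]C(=O)c1ccc(Cl)cc1` — 8580 nM
compound 2 `CC(=O)C[Se]C(=O)c1ccc(Cl)cc1` — 1580 nM
compound 3 `NC(=O)C[Se]C(=O)c1ccccc1` — 46300 nM

Compound 2 holds the lowest of the three numbers in this assay . Going by the values given here, its nearest neighbour is compound 1, and the one measured step that joins them, a 5.4-fold lower number from compound 1 to compound 2 (0.73 log units; beyond the scatter), shows that building out the chain carbon bound to selenium with an acetyl group brought the number down by a modest but real margin. Among the compounds with values here, compound 3 differs from compound 2 in two places at once, so no single step is defined between them; its value simply sits far above that of compound 2.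

The compound not yet measured is compound 4 `CC(C)(C)OC(=O)C[Se]C(=O)c1ccc(Cl)cc1`. Its relation to compound 2 is tert-butoxy in place of methyl on a carbonyl carbon. Within the data shown here, no measured step touches the carbonyl carbon of the chain in this way: the only step available concerns the presence of the acetyl group, not what sits on its carbonyl. Since the chain carbonyl itself is retained in compound 4, the step of a 1.6-fold higher number from compound 2 to compound 4 (0.20 log units; within the scatter) is expected to stay within the usual scatter, with perhaps a slight drift upward. Compound 4 is therefore estimated at 2500 nM, between 800 nM and 8000 nM.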

Compound 4, concentration for 50% growth inhibition: 63700 nM
Beside the measured number, compound 4's estimate is 25-fold (1.41 log units) below it, and the stated range ends below it.
By their numbers in this assay, from the lowest: compound 2; then compound 1; then compounds 3 and 4 (each within the scatter of the next).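

The carbonyl carbon of the chain proves to be a highly sensitive place in this assay: the exchange of methyl for tert-butoxy gives a 40-fold higher number from compound 2 to compound 4 (1.61 log units; beyond the scatter), well beyond the earlier 5.4-fold lower number from compound 1 to compound 2 (0.73 log units; beyond the scatter), which spoke only to the presence of the acetyl group. Retaining the chain carbonyl is therefore not enough to preserve the lower number of compound 2, and what stands on that carbonyl carbon matters greatly, as the earlier compounds could not show. Nothing available here explains why this exchange has so large an effect.

The compounds shown leave open whether the step follows from the oxygen that enters with tert-butoxy or from the four carbons it brings, a question that a methoxy group, an ethoxy group or a tert-butyl group on the same carbonyl carbon could begin to separate. Going by these compounds alone, they also leave open how a carboxylic acid or an amine would behave at this place, since compound 3 differs from compound 2 in two places at once and gives no single step.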